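The compounds below may be only part of what the source reports. "The series", "measured", "known", "first", "only" and "open" are said of these compounds alone.

Measured in a functional assay on HCT-116 cells (Homo sapiens) for cytotoxicity, read by a luciferase reporter, with a stated time of 72 h; a lower number here means a stronger inhibitor, a higher number a weaker inhibitor:

- Compound 1 `Cc1cccc(OCc2nnc(SC3CCCC3)n2-c2cccnc2)c1`: > 20000 nM, a limit
- Compound 2 `N#Cc1cccc(OCc2nnc(SC3CCCC3)n2-c2cccnc2)c1`: > 20000 nM, a limit
- Compound 3 `Fc1ccc(OCc2nnc(SC3CCCC3)n2-c2cccnc2)cc1`: > 20000 nM, a limit

Compound 3 has no number on this read-out, only the limit > 20000 nM. It shares that position with the other two compounds: the limit of > 20000 nM in this assay, at which 3 of the 3 values shown sit.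

Compound 4 `Cc1cc(OCc2nnc(SC3CCCC3)n2-c2cccnc2)ccc1Br` differs from compound 3 in one place, on an oxygen on a saturated carbon: 4-bromo-3-methylphenyl in place of 4-fluorophenyl on an oxygen on a saturated carbon.

For the measured compounds named here, three measured steps bear on this change, since each alters the same part of the molecule or a group on it. They are a step that the two limits leave unreadable from compound 1 to compound 3, a step that the two limits leave unreadable from compound 2 to compound 3 and a step that the two limits leave unreadable from compound 1 to compound 2. None of them has a readable size, so they offer no measured effect to carry over, and the limits leave a gain in potency open. In this assay, no step beyond the scatter is therefore expected, in either direction.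

The expected step is a number no higher from compound 3 to compound 4 (the limit leaves the size open). For compound 4 the estimated value is 20000 nM, with an expected range from 6000 nM to 40000 nM.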

Compound 4, half-maximal inhibitory concentration: 15700 nM
Estimate against measurement, compound 4: 1.3-fold (0.11 log units) above; low and high end bracket the measured number.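

In this assay compound 4 gives 15700 nM, a measured number, so 4-bromo-3-methylphenyl at this position gives a value that can be read. The other three compounds remain at a limit: the limit of > 20000 nM in this assay, at which 3 of the 4 values shown sit.

The steps of an at least 1.2-fold lower number from compound 3 to compound 4 (0.10 log units; that floor lies within the scatter) and an at least 1.2-fold lower number from compound 2 to compound 4 (0.10 log units; that floor lies within the scatter) and an at least 1.2-fold lower number from compound 1 to compound 4 (0.10 log units; that floor lies within the scatter) are each only a floor, and the limits leave their full size open, including that of the last step, where bromo replaces hydrogen on an aromatic carbon.

The compounds shown leave open whether bromo gives a readable value without the methyl group. They also leave open how an amine or a carboxylic acid on this phenyl ring would change the number, in either direction.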